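The source may hold more compounds than are shown below. What is called first, only, known or untested is meant among the compounds shown, and "the series" means these compounds.

Working notes on the series, where the group on a carbonyl carbon of the shared core varies. In an in vitro ADME assay on microsomes (Rattus norvegicus) for metabolic stability (on this read-out higher numbers stand for a longer-lived compound and lower numbers for a shorter-lived compound), compound 1 `CC[C@H](N)C(=O)N1CCc2c(C)c3c(n2-c2ccc(C(N)=O)c(c2)N[C@@H](C)[C@H](C)C1)CC(C)(C)CC3=O` gives > 0.5 h, which is a limit and not a number. Compound 2 `Cc1c2c(n3c1CCN(C(=O)C1(N)CC1)C[C@@H](C)[C@H](C)Nc1cc-3ccc1C(N)=O)CC(C)(C)CC2=O` gives > 0.5 h, also a limit. Within the data shown here, compound 3 `Cc1c2c(n3c1CCN(C(=O)C1(N)CCCC1)C[C@@H](C)[C@H](C)Nc1cc-3ccc1C(N)=O)CC(C)(C)CC2=O` gives 0.0833 h, the only actual number so far, and it stands lowest of the three: an at least 6.0-fold lower number from compound 1 to compound 3 (0.77 log units; beyond the scatter) and an at least 6.0-fold lower number from compound 2 to compound 3 (0.77 log units; beyond the scatter). The remaining measured step, a step that the two limits leave unreadable from compound 1 to compound 2, adds little.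

Compound 4 `Cc1c2c(n3c1CCN(C(=O)[C@@H](O)C(C)C)C[C@@H](C)[C@H](C)Nc1cc-3ccc1C(N)=O)CC(C)(C)CC2=O` is related to compound 3 by 1-hydroxy-2-methylpropyl in place of 1-aminocyclopentyl on a carbonyl carbon. The new group, 1-hydroxy-2-methylpropyl, has no ring. Among the measured compounds shown here, no measured step goes from an amino group to a hydroxy group, so the expectation is loose. It rests on the two steps into compound 3, an at least 6.0-fold lower number from compound 1 to compound 3 (0.77 log units; beyond the scatter) and an at least 6.0-fold lower number from compound 2 to compound 3 (0.77 log units; beyond the scatter), which suggest that 1-aminocyclopentyl is the group tied to the short-lived end in this assay. A moderate rise is therefore expected, with the estimated step being a 3.0-fold higher number from compound 3 to compound 4 (0.48 log units; beyond the scatter). Compound 4 is estimated at 0.25 h, with an expected range of 0.08 h to 0.6 h.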

Compound 4, half-life: 0.317 h
Beside the measured number, compound 4's estimate is 1.3-fold (0.10 log units) below it; measured number inside the range.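

In this assay, among these compounds, this change on a carbonyl carbon gives a 3.8-fold higher number from compound 3 to compound 4 (0.58 log units; beyond the scatter), the first step with a number at both ends, so its size can be read and not only bounded. Compound 4 carries no amino group and no ring, so neither is needed for a number higher than that of compound 3, although the change removes both together and the two cannot be told apart. The other two steps are an at least 1.5-fold lower number from compound 2 to compound 4 (0.19 log units; that floor lies within the scatter) and an at least 1.5-fold lower number from compound 1 to compound 4 (0.19 log units; that floor lies within the scatter), so compound 4 is not clearly set apart from either, and the comparison stops at a limit: the limit of > 0.5 h in this assay, at which 2 of the 4 values shown sit.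

The compounds shown leave open how 1-hydroxycyclopentyl would stand, which joins the five-membered ring of compound 3 to a hydroxy group. Also open, from the compounds shown here alone, is where 1-aminocyclobutyl would fall relative to the 1-aminocyclopropyl of compound 2 and the 1-aminocyclopentyl of compound 3.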